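Swapping the nucleobase on the silylated sugar core

A few compounds are considered here, and "the series" means these few. Any claim that something is new, unique, unknown or untested is made for them only; others in the source may bear on it.

Measured in a functional assay on Hs 683 cells (Homo sapiens) for inhibition, read by MTT assay, with a stated time of 72 h; on this read-out lower numbers stand for stronger inhibition of growth and higher numbers for weaker inhibition of growth:
- compound 1 `Cc1cn([C@@H]2O[C@H](CO[Si](C)(C)C(C)(C)C(C)C)[C@@H](O)[C@H]2O)c(=O)[nH]c1=O`: 64000 nM
- compound 2 `Cc1cn([C@@H]2O[C@H](CO[Si](c3ccccc3)(c3ccccc3)C(C)(C)C)[C@@H](O)[C@H]2O)c(=O)[nH]c1=O`: 27000 nM

For the measured compounds named here, only two numbers are available in this assay, so the series gives little to build on. Compound 2 has the lower of the two numbers, and its gap to compound 1 lies beyond the usual scatter. Both compounds carry the same group on the ring atom that bears a hydroxy group in neither case, and they differ only in the large group on the core.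

Compound 3 `CC(C)(C)[Si](OC[C@H]1O[C@@H](n2ccc(N)nc2=O)[C@H](O)[C@@H]1O)(c1ccccc1)c1ccccc1` keeps the large group of compound 2 and changes the other substituent on the core: a group of 8 heavy atoms (4 carbon, 3 nitrogen, 1 oxygen; one six-membered aromatic ring with 2 hetero atoms) in place of a group of 9 heavy atoms (5 carbon, 2 nitrogen, 2 oxygen; one six-membered aromatic ring with 2 hetero atoms), on a saturated ring carbon. Going by the values given here, no measured pair shows an exchange of this kind, so its size in this assay cannot be read from the data. The starting point for the expectation is compound 2 at 27000 nM.

The expected change, a 1.1-fold lower number from compound 2 to compound 3 (0.03 log units; within the scatter), is estimated to stay within the scatter, with no direction favoured. For compound 3 the estimated value is 25000 nM, with an expected range of 8000 nM to 80000 nM.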

Compound 3, concentration for 50% growth inhibition: 40000 nM
Beside the measured number, compound 3's estimate is 1.6-fold (0.20 log units) below it, and the stated range covers the measured number.
By their numbers in this assay, from the lowest: compounds 2, 3 and 1 (each within the scatter of the next, the first and the last beyond it).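

In this assay, for the compounds shown here, the first exchange at this position, a group of 8 heavy atoms in place of a group of 9 heavy atoms on a saturated ring carbon next to the ring oxygen, gives a 1.5-fold higher number from compound 2 to compound 3 (0.17 log units; within the scatter), so the two compounds cannot be told apart on this read-out. Going by these compounds alone, the earlier pair showed only that the large group on the core can matter, with compound 1 at 64000 nM and compound 2 at 27000 nM, a gap beyond the scatter; this step adds that the six-membered aromatic ring with 2 hetero atoms can be altered in this way with the large group held constant, without a change that the assay can resolve. Nothing available explains the outcome at this position.

As far as these compounds go, a single exchange between two closely related groups says little about how far this position can be altered, so whether a carboxylic acid or a longer chain on this saturated ring carbon would leave the read-out unchanged stays open. Also open, from the compounds shown here alone, is whether the same exchange gives a similar step when the smaller silyl group of compound 1 takes the place of the large group of compound 2.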